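Aryl ring substitution in the dioxolane-fused enone series

This account rests on a few compounds, and the source may have more. Where it says the series, first, only, none or still open, it means among the compounds named here.

Compound 1 `C=CC[C@H]1C[C@]2([C@@H](C)Cc3cc(N)c(OC)cc3F)OCOC2=CC1=O` and compound 2 `C=CC[C@H]1C[C@]2([C@@H](C)Cc3ccc(OC)cc3F)OCOC2=CC1=O` share the same core and differ only on the aromatic ring. In a functional assay on M14 cells (Homo sapiens) for antiproliferative activity, with a stated time of 72 h (a higher number here means a weaker inhibitor, a lower number a stronger inhibitor), compound 1 gives 29 nM, and in this assay compound 2 gives 14 nM. Within the data shown here, the step of a 2.1-fold lower number from compound 1 to compound 2 (0.32 log units; beyond the scatter) is the only measured pair so far; it shows that removing the amino group from the aromatic carbon gave the lower number. Compound 2 therefore holds the lowest number of the two measured, with compound 1 as its nearest neighbour at a higher number.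

Compound 3 `C=CC[C@H]1C[C@]2([C@@H](C)Cc3cc(F)c(OC)cc3F)OCOC2=CC1=O` is not yet measured. Relative to compound 2 the change is fluoro in place of hydrogen on an aromatic carbon. Among the measured compounds shown here, the same aromatic carbon is the site of the one measured step, but that step exchanged amino for hydrogen, so it bears on compound 3 only as a sign that a small substituent at this position moved the number by a modest amount and no more. A fluoro group is a different substituent, and nothing measured shows its effect here. The expectation for compound 3 is a step of a 1.1-fold higher number from compound 2 to compound 3 (0.03 log units; within the scatter), likely within the scatter of this assay. Compound 3 is therefore estimated at 15 nM, with a range from 6 nM to 38 nM.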

Compound 3, half-maximal inhibitory concentration: 30 nM
Beside the measured number, compound 3's estimate is 2.0-fold (0.30 log units) below it, within the range that was stated.
By their numbers in this assay, from the lowest: compound 2; then compounds 1 and 3 (each within the scatter of the next).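

At this aromatic carbon, ortho to a methoxy group and para to a fluoro group, fluoro in place of hydrogen gives a 2.1-fold higher number from compound 2 to compound 3 (0.33 log units; beyond the scatter) in this assay, so the higher number seen with amino is not confined to that one group. Fluoro and amino cannot be told apart here, with a 1.0-fold higher number from compound 1 to compound 3 (0.01 log units; within the scatter), and among these three compounds only the unsubstituted carbon of compound 2 stands apart, with the lowest number and its steps to both others beyond the scatter. Nothing measured on these compounds bears on the reason for this result.

Three substituents at one carbon do not show whether any group placed here gives the higher number, so a chloro, hydroxyl or methyl group at this carbon could fall with compound 2 or with compound 1 and compound 3. All three compounds also keep the methoxy group and the other fluoro group, which leaves open whether the same steps would appear with a hydroxyl or ethoxy group in place of that methoxy group.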